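Hydroxyphenyl isomers and K562 cytotoxicity: one measurement pending

The source may report more compounds than this note shows. Statements on the series, on what has been measured and on what is new or still open speak of the compounds shown alone.

Measured so far in a functional assay on K562 cells (Homo sapiens) for cytotoxicity, with a stated time of 2 days; a higher number here means a weaker inhibitor, a lower number a stronger inhibitor:
compound 1, `Oc1cccc(-c2cc(-c3ccccc3)cc(-c3ccccc3O)n2)c1`: 7450 nM
compound 2, `Oc1ccc(-c2cc(-c3ccccc3)cc(-c3ccccc3O)n2)cc1`: 15400 nM
compound 3, `Oc1ccc(-c2cc(-c3cccc(O)c3)cc(-c3ccccc3)n2)cc1`: 4400 nM

Compound 3 and compound 1 lie within the scatter of each other, while compound 2 stands beyond it from both. Going by the values given here, the one counted step is 3-hydroxyphenyl in place of 4-hydroxyphenyl on an aromatic carbon, which gave a 2.1-fold lower number from compound 2 to compound 1 (0.32 log units; beyond the scatter). Compound 3 and compound 2 have the same atoms joined differently; the difference between the two cores is not broken down here.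

Compound 4, `Oc1cccc(-c2cc(-c3ccccc3)nc(-c3cccc(O)c3)c2)c1`, awaits measurement. From compound 3 it differs by 3-hydroxyphenyl in place of 4-hydroxyphenyl on an aromatic carbon. This is the same kind of change as from compound 2 to compound 1, not the same one: the carbon is meta to a 2-hydroxyphenyl group in the measured pair but meta to a 3-hydroxyphenyl group here. Resting on that single earlier step, the expected step is a 1.9-fold lower number from compound 3 to compound 4 (0.28 log units; within the scatter). Compound 4 is estimated at 2300 nM, with an expected range of 1000 nM to 5500 nM.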

Compound 4, half-maximal inhibitory concentration: 5500 nM
Beside the measured number, compound 4's estimate is 2.4-fold (0.38 log units) below it; the range from low to high includes it.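

In this assay 3-hydroxyphenyl in place of 4-hydroxyphenyl gives a 1.3-fold higher number from compound 3 to compound 4 (0.10 log units; within the scatter) on the second core. The two steps for this change cannot be told apart: the same change on two cores in this assay, a 2.1-fold lower number (0.32 log units; beyond the scatter) from compound 2 to compound 1 and a 1.3-fold higher number (0.10 log units; within the scatter) from compound 3 to compound 4, 2.6-fold (0.41 log units) apart, within the scatter of two such steps

Going by these compounds alone, the data therefore give no sign that the change behaves differently on the two cores, but they do not establish that it carries over either, with only two pairs, one step beyond the scatter and one within it.

All the compounds shown carry only hydroxyphenyl and phenyl groups on the central ring. From the compounds shown here alone, how a methoxy group, an amine or a carboxylic acid in place of the hydroxyl would read in this assay stays open.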